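Replacing the 3-fluorophenyl on the sulfonyl sulfur

This account rests on a few compounds, and the source may have more. Where it says the series, first, only, none or still open, it means among the compounds named here.

Measured so far:
compound 1 `O=S(=O)(c1cccc(F)c1)c1cn(C2CCNC2)c2ncccc12` — 2.7 nM
compound 2 `O=S(=O)(c1cccc(C(F)(F)F)c1)c1cn(C2CCNC2)c2ncccc12` — 1.3 nM
compound 3 `CCN1CCC(n2cc(S(=O)(=O)c3cccc(F)c3)c3cccnc32)C1` — 8.3 nM

In an assay on HeLa cells for displacement of a labelled ligand from 5-hydroxytryptamine receptor 6 (Homo sapiens) (on this read-out higher numbers stand for weaker inhibition and lower numbers for stronger inhibition), compound 1 gives 2.7 nM, the second highest of the three numbers. The two measured steps from it are both modest: a 2.1-fold lower number from compound 1 to compound 2 (0.32 log units; beyond the scatter), and a 3.1-fold higher number from compound 1 to compound 3 (0.49 log units; beyond the scatter).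

Compound 4 `O=S(=O)(Cc1ccc(Cl)s1)c1cn(C2CCNC2)c2ncccc12` is a new variation on compound 1: (5-chlorothiophen-2-yl)methyl in place of 3-fluorophenyl on a sulfonyl sulfur. Neither measured step changes the whole group on the sulfonyl sulfur; the step to compound 2 only exchanges one substituent on that ring, and the step to compound 3 touches the amine. So the available steps bear on it only loosely, and the expectation is uncertain. A modest weakening is expected, a 3.0-fold higher number from compound 1 to compound 4 (0.47 log units; beyond the scatter), giving an estimated 8 nM for compound 4, within 2 nM to 35 nM.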

Compound 4, inhibition constant: 1 nM
Estimate against measurement, compound 4: 8.0-fold (0.90 log units) above; the whole stated range lies above it.
By their numbers in this assay, from the lowest: compounds 4 and 2 (each within the scatter of the next); then compound 1; then compound 3.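

In this assay, the whole 3-fluorophenyl on the sulfonyl sulfur can be exchanged with no loss of binding, with a 2.7-fold lower number from compound 1 to compound 4 (0.43 log units; beyond the scatter) as the result. This position therefore accepts more than a change of substituent on that ring: it also takes a five-membered aromatic ring carrying chlorine and joined through a methyl link. No supporting evidence accounts for this gain.

As far as these compounds go, whether the chlorine, the sulfur-containing ring or the link matters remains open, and a benzyl group would help separate them. Also open, from the compounds shown here alone, is how the new group behaves with the ethyl on the ring amine of compound 3.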